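Dropping a Tert-butoxycarbonyl Group on Two Related Cores

The source may report more compounds than this note shows. Statements on the series, on what has been measured and on what is new or still open speak of the compounds shown alone.

Three compounds have so far been tested in an ADME assay on RAW264.7 cells (Mus musculus) for cytotoxicity, read by WST assay (on this read-out lower numbers stand for higher toxicity in this test and higher numbers for lower toxicity in this test), and each result is a limit of the test rather than a number:
Compound 1 `CC(C)(C)OC(=O)N(Cc1ccco1)C(=O)c1ccc(CN2Cc3ccccc3S2(=O)=O)cc1` gives > 100000 nM.
Compound 2 `O=C(NCc1ccco1)c1ccc(CN2Cc3ccccc3S2(=O)=O)cc1` gives > 100000 nM.
Compound 3 `CC(C)(C)OC(=O)N(Cc1ccco1)C(=O)c1ccc(Cn2oc3ccccc3c2=O)cc1` gives > 100000 nM.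

Compound 2 differs from compound 1 by hydrogen in place of tert-butoxycarbonyl on an amide-type nitrogen. The size of a step that the two limits leave unreadable from compound 1 to compound 2 cannot be read because of the limit of > 100000 nM in this assay, at which 3 of the 3 values shown sit. Compound 3 differs from compound 1 in its core: a group of 10 heavy atoms (7 carbon, 1 nitrogen, 2 oxygen; one five-membered aromatic ring with 2 hetero atoms, one six-membered aromatic ring of carbon only) in place of a group of 11 heavy atoms (7 carbon, 1 nitrogen, 2 oxygen, 1 sulfur; one five-membered non-aromatic ring with 2 hetero atoms, one six-membered aromatic ring of carbon only), on a saturated chain carbon bound to an aromatic carbon. Here too a step that the two limits leave unreadable from compound 1 to compound 3, for the same reason.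

Compound 4 `O=C(NCc1ccco1)c1ccc(Cn2oc3ccccc3c2=O)cc1` has not yet been measured. It stands to compound 3 as compound 2 stands to compound 1, by the same change: hydrogen in place of tert-butoxycarbonyl on an amide-type nitrogen. Since no shown step can be sized, the estimate rests on the limit of > 100000 nM in this assay, at which 3 of the 3 values shown sit, and on a step that the two limits leave unreadable from compound 1 to compound 2, and so for compound 4 a step that the limit leaves unreadable from compound 3 to compound 4 is expected. Compound 4 is therefore estimated at 150000 nM, most likely again reported as a limit.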

Compound 4, concentration lethal to 50% of the cells: > 100000 nM
Compound 4 was reported as a limit (the forecaster's own chance of this, stated with the estimate: 85%); the middle value is on the limit's open side.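

No step can be read from compound 3 to compound 4, because both results are limits of the test: the limit of > 100000 nM in this assay, at which 4 of the 4 values shown sit. The compounds shown leave open whether swapping tert-butoxycarbonyl for hydrogen, or changing the core, alters the result in this assay at all.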